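Lengthening the Ester Chain from Compound 3 to Compound 4

The source may report more compounds than this note shows. Statements on the series, on what has been measured and on what is new or still open speak of the compounds shown alone.

Compound 1 `CCOC(=O)c1c(N)sc(-c2ccc(F)cc2)c1C`: 12000 nM
Compound 2 `CCOC(=O)c1c(N)sc(-c2ccccc2)c1-c1ccccc1`: 4500 nM
Compound 3 `COC(=O)c1c(N)sc(-c2ccccc2)c1C`: 4100 nM

Three compounds sharing one core have been run in an in vitro functional assay on HEK293 cells for antagonist activity at metabotropic glutamate receptor 6 (Homo sapiens), read by reporter gene assay, luminescence and calcium flux, tested at 10 uM; on this read-out higher numbers stand for weaker inhibition and lower numbers for stronger inhibition. In this assay compound 3 gives 4100 nM, the lowest of the three numbers. Its gap to compound 2, which gives 4500 nM, lies within the usual scatter, so the two cannot be told apart on this read-out. Only compound 1, with 12000 nM, lies beyond the scatter from compound 3, though compound 1 differs from compound 3 in more than one place, so no single step can be read from that pair.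

Compound 4 `CCCOC(=O)c1c(N)sc(-c2ccccc2)c1C` has not yet been measured. It differs from compound 3 by one change: ethyl in place of hydrogen on a saturated chain carbon bound to an oxygen next to a carbonyl group. Among the measured compounds shown here, no pair among the measured compounds isolates this kind of change, so the expectation rests on the general run of the three numbers, which all sit within a narrow band. The step from compound 3 to compound 4 in this assay is expected to be small, a 1.5-fold higher number from compound 3 to compound 4 (0.17 log units; within the scatter), with a slight lean toward a higher number, and not clearly beyond the scatter. Compound 4 is therefore estimated at 6000 nM, within a range of 2000 nM to 20000 nM.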

Compound 4, half-maximal inhibitory concentration: 2400 nM
Compound 4: middle estimate off by 2.5-fold (0.40 log units), on the high side; low and high end bracket the measured number.
By their numbers in this assay, from the lowest: compounds 4, 3 and 2 (each within the scatter of the next); then compound 1.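

Among the compounds shown here, this is the first pair that isolates a change at the ester, and in this assay the move from methoxycarbonyl to propoxycarbonyl gives a 1.7-fold lower number from compound 3 to compound 4 (0.23 log units; within the scatter), so the two compounds cannot be told apart on this read-out. The saturated chain carbon bound to the oxygen next to the carbonyl group therefore accepts an added ethyl with no loss of inhibition beyond the scatter, and neither a clear gain nor a clear loss can be claimed for this single step. Nothing in the available evidence accounts for the size of this step or bears on what lies behind it.

From the compounds shown here alone, whether a longer chain such as butyl, a branched group such as isopropyl, or a carboxylic acid or an amide in place of the ester would move the number beyond the scatter remains open, as does how the ethoxycarbonyl analogue of compound 3 would read. Also open, going by these compounds, is whether the same change would behave alike on the core of compound 1 or of compound 2, which differ from compound 3 in more than the ester alone.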